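A few compounds are considered here, and "the series" means these few. Any claim that something is new, unique, unknown or untested is made for them only; others in the source may bear on it.

Compounds measured so far in an assay on isolated protein for inhibition of histone deacetylase 8 (Homo sapiens), with a stated time of 1 h; a lower number here means a stronger inhibitor, a higher number a weaker inhibitor:

Compound 1 `Cc1ccc(NC(=O)COc2ccc3cc(/C=C4/SC(=O)NC4=O)ccc3c2)cc1` — 9000 nM
Compound 2 `COc1cccc(NC(=O)COc2ccc3cc(/C=C4/SC(=O)NC4=O)ccc3c2)c1` — 7600 nM
Compound 3 `O=C(COc1ccc2cc(/C=C3/SC(=O)NC3=O)ccc2c1)Nc1ccc(F)cc1` — 6600 nM

Three compounds share one core and differ only in the aryl group on the amide-type nitrogen. In this assay compound 3 gives the lowest of the three numbers, but every gap to it is within the scatter: a 1.4-fold lower number from compound 1 to compound 3 (0.13 log units; within the scatter) and a 1.2-fold lower number from compound 2 to compound 3 (0.06 log units; within the scatter) are both small, as is a 1.2-fold lower number from compound 1 to compound 2 (0.07 log units; within the scatter). None of the three can therefore be set apart from the others.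

Compound 4 `O=C(COc1ccc2cc(/C=C3/SC(=O)NC3=O)ccc2c1)Nc1ccc(Cl)c(Cl)c1` has not yet been measured. It keeps the core of compound 3 and changes only the aryl group: 3,4-dichlorophenyl in place of 4-fluorophenyl on an amide-type nitrogen. Two of the measured steps bear on this kind of change, since each of them also exchanges substituents on that same aryl group, and both stayed within the scatter. For the measured compounds named here, nothing among the measured compounds shows a dichloro pattern, so the expectation rests on those two steps alone: a step in this assay that does not rise beyond the scatter, in either direction, is expected, a 1.1-fold lower number from compound 3 to compound 4 (0.04 log units; within the scatter). The value of compound 4 is estimated at 6000 nM, with a range from 2500 nM to 14000 nM.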

Compound 4, half-maximal inhibitory concentration: > 50000 nM
Compound 4 gave a limit, no number (the forecaster's own chance of this, stated with the estimate: 5%); at least 8.3-fold (0.92 log units) between middle value and limit.
By their numbers in this assay, from the lowest: compounds 3, 2 and 1 (each within the scatter of the next). At a limit, above all of these: compound 4.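

In this assay compound 4 gives a limit of the assay and not a number, and it stands alone there: the limit of > 50000 nM in this assay, at which 1 of the 4 values shown sits.

The three earlier compounds had made the aryl group on the amide-type nitrogen look open to exchange, but 3,4-dichlorophenyl shows that this position does respond to a change in that group, with an at least 7.5-fold higher number from compound 3 to compound 4 (0.87 log units; beyond the scatter), an at least 6.5-fold higher number from compound 2 to compound 4 (0.81 log units; beyond the scatter) and an at least 5.5-fold higher number from compound 1 to compound 4 (0.74 log units; beyond the scatter). All three steps are beyond the scatter, and as they rest on a limit, they fix only the smallest possible size of the change. Of the four aryl groups, 3,4-dichlorophenyl is the only one that carries chlorine and the only one that carries two substituents, so this single compound ties the change to neither feature on its own.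

The compounds shown leave open whether a 4-chlorophenyl or a 3-chlorophenyl group would already reach the same limit, or whether a 3,4-difluorophenyl or 3,4-dimethylphenyl group would do so without any chlorine. They also leave open how far the true value of compound 4 lies past its limit.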